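Swapping the Aryl Group on the Shared Core

This account rests on a few compounds, and the source may have more. Where it says the series, first, only, none or still open, it means among the compounds named here.

Compound 2 `CCc1ccc(-c2cn3ccnc3c(-c3ccc4ncn(Cc5ccccc5)c4c3)n2)cc1`: 31.2%
Compound 1 `Fc1ccccc1-c1cn2ccnc2c(-c2ccc3ncn(C4CCCCC4)c3c2)n1`: 0.17%

In a functional assay on OVCAR-3 cells (Homo sapiens) for inhibition, read by sulforhodamine B assay, with a stated time of 48 h, tested at 10 uM (a lower number here means less inhibition, a higher number more inhibition at the concentration tested (going by the name of the read-out)), compound 2 gives 31.2%, the higher of the two numbers shown. Compound 1 gives 0.17%, and the gap between them lies beyond the usual scatter. Compound 3 `Cc1cccc(-c2cn3ccnc3c(-c3ccc4ncn(Cc5ccccc5)c4c3)n2)c1` differs from compound 2 in one place: 3-methylphenyl in place of 4-ethylphenyl on an aromatic carbon. Among the compounds with values here, no measured pair shows a change of this kind, so the size of the step is uncertain. The step from compound 2 to compound 3 is expected to be small, likely within the scatter, estimated as a number 5.2 percentage points lower from compound 2 to compound 3 (within the scatter). Compound 3 is expected to give about 26%, with a range from 5% to 50%.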

Compound 3, a percentage reported as inhibition, at one concentration (the size of the read-out at that concentration, not a potency): 14%
Beside the measured number, compound 3's estimate is 12 percentage points above it, within the range that was stated.
By their numbers in this assay, from the lowest: compound 1; then compound 3; then compound 2.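

Taking 3-methylphenyl in place of 4-ethylphenyl on the shared core gives a number 17.2 percentage points lower from compound 2 to compound 3 (beyond the scatter) in this assay. This is the first step shown between compounds that differ in one place. It shows that this position responds even when one carbon-only aryl group replaces another, with no hydrogen-bond donors or acceptors added or lost on either side.

Still open, from the compounds shown here alone, is whether the group's size or its point of attachment matters more, which 4-methylphenyl or 3-ethylphenyl could separate, and how an aminophenyl or carboxyphenyl group would read here. Nothing measured among these compounds explains the step.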